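The compounds below may be only part of what the source reports. "The series", "measured", "known", "first", "only" and "open" are said of these compounds alone.

Of the compounds shown here, three have so far been tested in a functional assay on the whole organism for inhibition, with Mus musculus as the target, in the writhing test, with stated times of 3 days and 20 min, at a dose of 30 mg/kg by the oral route; a lower number here means less inhibition, a higher number more inhibition at the dose given (going by the name of the read-out). Compound 1, `Cc1ccc(-c2cc(C)n(S(=O)(=O)Oc3ccccc3Cl)n2)cc1`, gives 48.5% in this assay. Compound 2, `Cc1cc(-c2ccc(C(F)(F)F)cc2)nn1S(=O)(=O)Oc1ccccc1`, gives 25.8%. Compound 3, `CCc1ccc(-c2cc(C)n(S(=O)(=O)Oc3ccccc3)n2)cc1`, gives 48.1%, which places it second highest of the three: its number and that of compound 1 lie within the scatter of each other, while compound 2 sits clearly below it. Going by the values given here, the single measured step, a number 22.3 percentage points higher from compound 2 to compound 3 (beyond the scatter), came from putting ethyl in place of trifluoromethyl on an aromatic carbon of the group attached to the shared core.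

Compound 4, `Cc1cc(-c2ccccn2)nn1S(=O)(=O)Oc1ccccc1`, has not yet been measured. It differs from compound 3 in one place: pyridin-2-yl in place of 4-ethylphenyl on an aromatic carbon. The whole 4-ethylphenyl group leaves and pyridin-2-yl enters on an aromatic carbon of the five-membered aromatic ring with 2 nitrogen, next to the ring nitrogen. Among the compounds with values here, no measured step swaps the entire ring. Compound 4 is nevertheless expected to drop, by a number 13.1 percentage points lower from compound 3 to compound 4 (beyond the scatter), because a number 22.3 percentage points higher from compound 2 to compound 3 (beyond the scatter) showed the ethyl-bearing ring going with the higher number, and that ring is lost here. The estimate for compound 4 is 35%, in a range from 15% to 55%.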

Compound 4, a percentage reported as inhibition, in the whole organism at one dose (the size of the read-out at that dose, not a potency): 15%
For compound 4 the middle estimate is 20 percentage points above the measured one; low and high end bracket the measured number.
By their numbers in this assay, from the lowest: compound 4; then compound 2; then compounds 3 and 1 (each within the scatter of the next).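

In this assay, putting pyridin-2-yl in place of 4-ethylphenyl on this aromatic carbon of the five-membered ring gives a number 33.1 percentage points lower from compound 3 to compound 4 (beyond the scatter), a large step. The earlier step, a number 22.3 percentage points higher from compound 2 to compound 3 (beyond the scatter), changed only the group carried by the six-membered carbon ring, whereas this one shows that exchanging the whole ring at this position also moves the number well beyond the scatter. The change removes the ethyl group, shortens the substituent and brings in a ring nitrogen all at once, and nothing available explains the fall.

The compounds shown leave open whether the loss of the ethyl group or the arrival of the ring nitrogen accounts for the step, and a plain phenyl group or a pyridin-2-yl ring carrying an ethyl group on this carbon would help to separate the two. Also open, on these data alone, is how this assay would respond to a methoxy group, an amine or a longer chain such as propyl on the six-membered ring.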